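The source may hold more compounds than are shown below. What is called first, only, known or untested is meant among the compounds shown, and "the series" means these compounds.

Measured compounds:
- compound 1 `Nc1scc(CN2CCN(c3ccc(Cl)cc3F)CC2)c1C(=O)c1ccc(Cl)cc1`; in an assay on CHO cells for displacement of a labelled ligand from adenosine receptor A1 (Homo sapiens), read by scintillation counting, with a stated time of 120 min, tested at 10 uM (a lower number here means less inhibition, a higher number more inhibition at the concentration tested (going by the name of the read-out)), compound 1 gives 0%
- compound 2 `Nc1scc(CN2CCN(c3ccc(C(F)(F)F)cc3)CC2)c1C(=O)c1cccc(C(F)(F)F)c1`; in this assay compound 2 gives 0%

Compound 2 stands level with compound 1 in this assay at the digits recorded; the two values lie within the scatter of each other, and neither shows measurable displacement at the test concentration. Within the data shown here, no step between measured compounds is available for this series, so nothing on the size of an effect of any group on the amine nitrogen in the ring can be read from the numbers.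

Compound 3 `Nc1scc(CN2CCN(c3cccc(F)c3)CC2)c1C(=O)c1cccc(C(F)(F)F)c1` is the next compound; it differs from compound 2 as follows: 3-fluorophenyl in place of 4-(trifluoromethyl)phenyl on an amine nitrogen in a ring

Both measured compounds give no inhibition, and the change is a smaller substituted phenyl for a larger one at the same place. The step of a number 2 percentage points higher from compound 2 to compound 3 (within the scatter) is expected to be none beyond the scatter. Compound 3 is estimated at 2% in this assay, with a range from 0% to 12%.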

Compound 3, a percentage reported as inhibition, at one concentration (the size of the read-out at that concentration, not a potency): 0%
Estimate against measurement, compound 3: 2 percentage points above, within the range that was stated.
By their numbers in this assay, from the lowest: compounds 1, 2 and 3 (each within the scatter of the next).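

Among these compounds, the first readable step at this position, on an amine nitrogen in a ring, is 3-fluorophenyl in place of 4-(trifluoromethyl)phenyl, and in this assay it shows no change at the digits printed from compound 2 to compound 3 (within the scatter) for this swap. Compound 3 gives 0% in this assay with a phenyl group of fewer heavy atoms at this place, so neither of these two aryl groups gives measurable displacement at the concentration tested. Nothing at hand bears on the reason for this result.

With all the readings the same, the compounds shown leave open whether any group at this place can produce displacement in this assay on the shared core. On these data alone, whether a pyridine ring, or a phenyl ring carrying a carboxylic acid, would move the read-out also remains open.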